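Amine substituent variation in the shared-core series

The source may hold more compounds than are shown below. What is called first, only, known or untested is meant among the compounds shown, and "the series" means these compounds.

Measured in a functional assay on DLD-1 cells (Homo sapiens) for inhibition, read by MTT assay, with a stated time of 72 h; on this read-out higher numbers stand for weaker inhibition and lower numbers for stronger inhibition:
compound 1 `COc1ccc(CNCc2c(OC)cc(Oc3cccc(Nc4ccccc4)c3)cc2OC)cc1` gives 1910 nM
compound 2 `COc1cc(Oc2cccc(Nc3ccccc3)c2)cc(OC)c1CNCc1ccc(F)cc1` gives 2650 nM
compound 3 `COc1cc(Oc2cccc(Nc3ccccc3)c2)cc(OC)c1CNCCNC(C)=O` gives 6010 nM

Compound 3 stands highest of the three on this read-out: a 3.1-fold higher number from compound 1 to compound 3 (0.50 log units; beyond the scatter) and a 2.3-fold higher number from compound 2 to compound 3 (0.36 log units; beyond the scatter), both beyond the scatter, while the change from compound 1 to compound 2 stays within it: a 1.4-fold higher number from compound 1 to compound 2 (0.14 log units; within the scatter).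

Compound 4 `COc1cc(Oc2cccc(Nc3ccccc3)c2)cc(OC)c1CNCc1ccc(C)cc1` differs from compound 3 by 4-methylphenyl in place of acetamidomethyl on a saturated chain carbon bound to an amine nitrogen. This reverses the kind of change seen in the two measured steps into compound 3, where an arylmethyl group gave way to acetamidomethyl and the number rose modestly. Returning to an arylmethyl group is therefore expected to lower the number by a modest step, a 2.7-fold lower number from compound 3 to compound 4 (0.44 log units; beyond the scatter), back towards the values of compound 1 and compound 2. Compound 4 is estimated at 2200 nM, with a range of 1200 nM to 4200 nM.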

Compound 4, half-maximal inhibitory concentration: 6080 nM
Estimate against measurement, compound 4: 2.8-fold (0.44 log units) below; the whole stated range lies below it.
By their numbers in this assay, from the lowest: compounds 1 and 2 (each within the scatter of the next); then compounds 3 and 4 (each within the scatter of the next).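

At this position, an aryl ring in place of acetamidomethyl does not by itself bring the number down: 4-methylphenyl and acetamidomethyl read alike (a 1.0-fold higher number from compound 3 to compound 4 (0.01 log units; within the scatter)). The substituent on that ring now counts, since methyl in place of fluoro (a 2.3-fold higher number from compound 2 to compound 4 (0.36 log units; beyond the scatter)) and methyl in place of methoxy (a 3.2-fold higher number from compound 1 to compound 4 (0.50 log units; beyond the scatter)) both give modest rises, although fluoro and methoxy themselves stayed within the scatter. Nothing available accounts for this result. Still open, going by these compounds, is how a 4-chlorophenyl group, a 4-carboxyphenyl group or a longer chain would read at this position.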